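Swapping the Amide Substituent in Compound 2

A few compounds are considered here, and "the series" means these few. Any claim that something is new, unique, unknown or untested is made for them only; others in the source may bear on it.

Two compounds have been measured so far in a functional assay on HepG2 cells (Homo sapiens) for cytotoxicity, read by MTT assay, with a stated time of 48 h; on this read-out higher numbers stand for weaker inhibition and lower numbers for stronger inhibition:
compound 1 `CC1=NN(C(=O)c2ccc(C)cc2)C(c2cc(Br)ccc2O)C1` gives 23200 nM;
compound 2 `Cc1ccc(C(=O)N2N=C(c3cc4ccccc4oc3=O)CC2c2ccccc2)cc1` gives 52300 nM.

In this assay compound 2 stands highest of these two numbers, with compound 1 the nearer one at a lower number, a gap beyond the usual scatter. Compound 3 `CN1CCN(CC(=O)N2N=C(c3cc4ccccc4oc3=O)CC2c2ccccc2)CC1` has not yet been measured. It differs from compound 2 in one place: (4-methylpiperazin-1-yl)methyl in place of 4-methylphenyl on a carbonyl carbon. Within the data shown here, no measured pair shows this change, so the step is unknown. In this assay the step of a 1.1-fold higher number from compound 2 to compound 3 (0.06 log units; within the scatter) is expected to stay within the scatter. Compound 3 is therefore estimated at 60000 nM, with a range from 20000 nM to 150000 nM.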

Compound 3, half-maximal inhibitory concentration: 33100 nM
For compound 3 the middle estimate is 1.8-fold (0.26 log units) above the measured one; the range from low to high includes it.
By their numbers in this assay, from the lowest: compounds 1, 3 and 2 (each within the scatter of the next, the first and the last beyond it).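

In this assay, replacing 4-methylphenyl with (4-methylpiperazin-1-yl)methyl on this carbonyl carbon gives a 1.6-fold lower number from compound 2 to compound 3 (0.20 log units; within the scatter) and so makes no clear difference. This single pair shows that an aromatic carbon ring can give way to a non-aromatic ring with 2 hetero atoms without moving the number beyond the scatter. No measurement shown bears on the reason for this result. As far as these compounds go, whether a morpholine ring or a dimethylamino group would do the same in place of the 4-methylpiperazin-1-yl part remains open. So does whether this swap behaves alike on the core of compound 1.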